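Furan in Place of Benzofuran on a Nucleoside Core

A few compounds are considered here, and "the series" means these few. Any claim that something is new, unique, unknown or untested is made for them only; others in the source may bear on it.

Compound 1 `COc1ncnc2c1c(I)cn2[C@@H]1O[C@H](CO)[C@@H](O)[C@H]1O` gives > 20000 nM in a functional assay on K562 cells (Homo sapiens), read by MTT assay, with a stated time of 72 h (on this read-out lower numbers stand for stronger inhibition and higher numbers for weaker inhibition), which is a limit of the assay and not a number.
Compound 2 `COc1nc(N)nc2c1c(-c1ccco1)cn2[C@@H]1O[C@H](CO)[C@@H](O)[C@H]1O` gives > 20000 nM in this assay, again a limit.
Compound 3 `COc1ncnc2c1c(-c1cc3ccccc3o1)cn2[C@@H]1O[C@H](CO)[C@@H](O)[C@H]1O` gives 20900 nM in this assay.

Compound 3 is the only one of the three with an actual number; the other two values are limits, so it cannot be placed in any order against them. Among the measured compounds shown here, the single one-place step, a step that the limit leaves unreadable from compound 1 to compound 3, stays unreadable due to the limit of > 20000 nM in this assay, at which 2 of the 3 values shown sit.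

Compound 4 `COc1ncnc2c1c(-c1ccco1)cn2[C@@H]1O[C@H](CO)[C@@H](O)[C@H]1O` differs from compound 3 in one place: furan-2-yl in place of 1-benzofuran-2-yl on an aromatic carbon. For the measured compounds named here, compound 2 also carries furan-2-yl, but it differs from compound 4 in a second place as well, so no single step joins them. Its value is a limit.

Going by the values given here, no measured step therefore bears on this change with a readable size. With compound 3 already at the edge of what the assay reports, compound 4 is expected to show no change beyond the scatter in this assay, and quite possibly only a limit. Compound 4 is estimated at 25000 nM, within 10000 nM to 60000 nM. The expected step is a 1.2-fold higher number from compound 3 to compound 4 (0.08 log units; within the scatter).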

Compound 4, half-maximal inhibitory concentration: 60 nM
Compound 4: the middle estimate sits 420-fold (2.62 log units) above what was measured; the measured number lies below the stated range.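

In this assay, among the compounds shown here, this carbon proves far from indifferent to what it carries, a point the earlier compounds could not show: furan-2-yl in place of 1-benzofuran-2-yl gives a 350-fold lower number from compound 3 to compound 4 (2.54 log units; beyond the scatter). Furan-2-yl in place of iodo gives an at least 330-fold lower number from compound 1 to compound 4 (2.52 log units; beyond the scatter), so among the groups shown at this place only furan-2-yl brings a low number. Furan-2-yl alone does not suffice, since hydrogen in place of amino on an aromatic carbon of the core gives an at least 330-fold lower number from compound 2 to compound 4 (2.52 log units; beyond the scatter), and this step and the one from iodo are bounds only: the limit of > 20000 nM in this assay, at which 2 of the 4 values shown sit.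

The compounds shown leave open whether another single ring on this carbon, such as thiophen-2-yl or phenyl, would keep a number like that of compound 4. They also leave open whether an amine in place of the methoxy group would do so.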